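The source may hold more compounds than are shown below. What is called first, only, known or untested is meant among the compounds shown, and "the series" means these compounds.

Of the compounds shown here, three built on a shared core have been measured in an assay on isolated protein for inhibition of leukotriene B4 receptor 1 (Homo sapiens), tested at 10 uM; on this read-out higher numbers stand for more inhibition at the one concentration tested (going by the name of the read-out) and lower numbers for less inhibition. Compound 1 `CCc1cc(C(C)=O)c(O)cc1OCCCCC#N` gives 92% in this assay. Compound 2 `CC(=O)c1cc(CC2CO2)c(OCCCCC#N)cc1O` gives 62% in this assay, and compound 3 `CCc1cc(C(C)=O)c(O)cc1OCCCCCCC#N` gives 103% in this assay. Compound 3 therefore stands highest of the three numbers, with compound 1 nearest and compound 2 furthest, and both gaps lie beyond the scatter. Two single changes link these values: a number 30 percentage points lower from compound 1 to compound 2 (beyond the scatter), and a number 11 percentage points higher from compound 1 to compound 3 (beyond the scatter).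

Compound 4 `CC(=O)c1cc(CO)c(OCCCCCCC#N)cc1O` has not yet been measured. It differs from compound 3 in one place:
hydroxy in place of methyl on a saturated chain carbon bound to an aromatic carbon
The step from compound 1 to compound 2 is the one that bears on this, since it also exchanged the methyl on a saturated chain carbon bound to an aromatic carbon, and it brought a modest fall beyond the scatter. The step from compound 1 to compound 3 concerns a different place, the longer chain, which compound 4 keeps unchanged. Among the measured compounds shown here, no measured step exchanges methyl for hydroxy at that place, so the expectation rests on the one comparable step alone. Because of a number 30 percentage points lower from compound 1 to compound 2 (beyond the scatter), a modest fall beyond the scatter is expected for compound 4, with the step estimated as a number 23 percentage points lower from compound 3 to compound 4 (beyond the scatter). Compound 4 is thus estimated at 80% in this assay, with a range from 58% to 100%.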

Compound 4, a percentage reported as inhibition, at one concentration (the size of the read-out at that concentration, not a potency): 40%
Compound 4: middle estimate off by 40 percentage points, on the high side; the measured number lies below the stated range.
By their numbers in this assay, from the lowest: compound 4; then compound 2; then compound 1; then compound 3.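

In this assay, among the compounds shown here, turning the ethyl group into hydroxymethyl, with hydroxy in place of methyl on a saturated chain carbon bound to an aromatic carbon, gives a number 63 percentage points lower from compound 3 to compound 4 (beyond the scatter) and counts as a large step, whereas the only earlier change at this place, oxiran-2-yl in place of methyl on the shorter chain, gave the modest a number 30 percentage points lower from compound 1 to compound 2 (beyond the scatter) on the same read-out. Both exchanges seen at this place lower the number, none of the compounds shown goes against that, and the new result adds that a single heavy atom exchanged here, carbon for oxygen with one hydrogen-bond donor and one hydrogen-bond acceptor entering, is enough for a large step, even with the longer chain kept that accompanied a number 11 percentage points higher from compound 1 to compound 3 (beyond the scatter) on the ethyl compounds. Nothing available explains why this exchange costs so much.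

The compounds shown leave open whether a methoxy group, an amine or a carboxylic acid at this place would give a fall of similar size, and whether a longer chain ending in hydroxy would behave as hydroxymethyl does. They also leave open how hydroxymethyl reads on the shorter chain of compound 1 , so the size of this step is known on the longer chain only.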